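A few compounds are considered here, and "the series" means these few. Any claim that something is new, unique, unknown or untested is made for them only; others in the source may bear on it.

Compound 1 `Fc1cccc(F)c1Cn1ccc2nc(-c3ccccc3)nc-2c1`, compound 2 `Cc1cccc(Cn2ccc3nc(-c4ccccc4)nc-3c2)c1` and compound 3 `COc1ccccc1Cn1ccc2nc(-c3ccccc3)nc-2c1` share one core and differ in the group on a saturated chain carbon bound to an aromatic nitrogen. In an ADME assay on MDBK cells (Bos taurus) for cytotoxicity (a higher number here means that more compound is tolerated, a lower number that less compound is tolerated), compound 1 gives > 100000 nM, which is a limit. Compound 2 gives > 100000 nM, also a limit. Compound 3 gives > 100000 nM, again a limit and not a number. All three therefore stand at the limit of > 100000 nM in this assay, at which 3 of the 3 values shown sit.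

Compound 4 `COc1cccc(Cn2ccc3nc(-c4ccccc4)nc-3c2)c1` has 3-methoxyphenyl in place of 2-methoxyphenyl at that place: 3-methoxyphenyl in place of 2-methoxyphenyl on a saturated chain carbon bound to an aromatic nitrogen. The measured steps that bear on this are a step that the two limits leave unreadable from compound 1 to compound 3 and a step that the two limits leave unreadable from compound 2 to compound 3, and neither gives a size. No change beyond the usual scatter is expected in this assay, and the estimated step is a number no higher from compound 3 to compound 4 (the limit leaves the size open). Compound 4 is estimated at 100000 nM, with an expected range of 50000 nM to 200000 nM.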

Compound 4, half-maximal cytotoxic concentration: > 100000 nM
Compound 4 gave a limit, no number (the forecaster's own chance of this, stated with the estimate: 90%); the middle value sits exactly at the limit.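

Compound 4 also gives only a limit, like compound 1, compound 2 and compound 3, so no step among these four can be read: the limit of > 100000 nM in this assay, at which 4 of the 4 values shown sit.

The compounds shown leave open whether changing this group makes any difference in this assay.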